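From Cyclopropylsulfamoyl to Trifluoromethyl in Liver Microsomes

The compounds below may be only part of what the source reports. "The series", "measured", "known", "first", "only" and "open" are said of these compounds alone.

In an in vitro ADME assay on microsomes from liver (Homo sapiens) for metabolic stability (on this read-out higher numbers stand for a longer-lived compound and lower numbers for a shorter-lived compound), compound 3 `COc1ccc(-c2cc(-c3ccc(S(=O)(=O)NC4CC4)cc3)cnc2N)cn1` gives 1.9 h. Compound 1 `CNS(=O)(=O)c1ccc(-c2cnc(N)c(-c3ccc(OC)nc3)c2)cc1` gives 3.02 h, and the two stand within the scatter of each other, with a 1.6-fold lower number from compound 1 to compound 3 (0.20 log units; within the scatter). Compound 2 `COc1ccc(-c2cc(-c3ccc(S(N)(=O)=O)cc3)cnc2N)cn1` gives > 4.16 h, which is a limit of the assay. Compound 4 `COc1ccc(-c2cc(-c3ccc(C(F)(F)F)cc3)cnc2N)cn1` departs from compound 3 through (trifluoromethyl in place of cyclopropylsulfamoyl on an aromatic carbon), placing trifluoromethyl where cyclopropylsulfamoyl stood on an aromatic carbon. The measured steps alter only the sulfonamide nitrogen, and they include an at least 1.3-fold higher number from compound 1 to compound 2 (0.13 log units; that floor lies within the scatter) and an at least 2.1-fold lower number from compound 2 to compound 3 (0.34 log units; beyond the scatter). None removes the whole group, so they offer only loose guidance. No clear direction is therefore expected in this assay, and the expected step is a 1.2-fold higher number from compound 3 to compound 4 (0.06 log units; within the scatter), inside the scatter. The estimate for compound 4 is 2.2 h, with an expected range from 0.9 h to 5.5 h.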

Compound 4, half-life: 4.75 h
For compound 4 the middle estimate is 2.2-fold (0.33 log units) below the measured one; the measured number falls inside the stated range.
By their numbers in this assay, from the lowest: compounds 3, 1 and 4 (each within the scatter of the next, the first and the last beyond it).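

In this assay, trifluoromethyl in place of the whole cyclopropylsulfamoyl on this aromatic carbon gives a 2.5-fold higher number from compound 3 to compound 4 (0.40 log units; beyond the scatter), a change that the nitrogen-only steps could not show. The same replacement of methylsulfamoyl gives a 1.6-fold higher number from compound 1 to compound 4 (0.20 log units; within the scatter), so the gain is read against the cyclopropyl compound alone. Compound 2 carries a limit of the assay, so its step to compound 4 cannot be read: the limit of > 4.16 h in this assay, at which 1 of the 4 values shown sits.

The compounds shown leave open whether the step comes from losing the sulfonamide or from gaining trifluoromethyl. A nitrile or a methyl group on this carbon would bear on that question.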